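Removing a chloro next step: compound 3 to compound 4

The source may report more compounds than this note shows. Statements on the series, on what has been measured and on what is new or still open speak of the compounds shown alone.

Measured in a functional assay on MDA-MB-231 cells (Homo sapiens) for inhibition, read by sulforhodamine B assay, with a stated time of 48 h, tested at 10 uM; on this read-out lower numbers stand for a stronger effect and higher numbers for a weaker effect at the one concentration tested:
compound 1 `O=C(Nc1cccc(-n2cc(-c3ccncc3)c(-c3cc(O)cc(Cl)c3)n2)c1)Nc1ccc(Cl)c(C(F)(F)F)c1` gives -47.3%
compound 2 `O=C(Nc1cccc(-n2cc(-c3ccncc3)c(-c3cc(O)cc(Cl)c3)n2)c1)Nc1ccc(Cl)c(Cl)c1` gives -38.1%
compound 3 `COc1cc(Cl)cc(-c2nn(-c3cccc(NC(=O)Nc4ccc(Cl)c(C(F)(F)F)c4)c3)cc2-c2ccncc2)c1` gives -30.8%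

Compound 3 shows the highest of the three numbers. Its nearest neighbour is compound 2, which lies within the scatter of it, so these two cannot be told apart on this assay; compound 1 sits beyond the scatter below it, as the step of a number 16.5 percentage points higher from compound 1 to compound 3 (beyond the scatter) records, where a methyl replaced a hydrogen on the oxygen.

Compound 4 `COc1cc(Cl)cc(-c2nn(-c3cccc(NC(=O)Nc4cccc(C(F)(F)F)c4)c3)cc2-c2ccncc2)c1` differs from compound 3 in one place: hydrogen in place of chloro on an aromatic carbon. The chloro sits on the aromatic carbon ortho to the trifluoromethyl group, para to a large group, and simply gives way to hydrogen.

For the measured compounds named here, no measured step removes a substituent from that ring. The closest comparison is a number 9.2 percentage points higher from compound 1 to compound 2 (within the scatter), which altered the group on the same ring and stayed within the scatter. That suggests changes at this ring move this assay little, though a single step is thin ground. The expected step of a number 5.8 percentage points higher from compound 3 to compound 4 (within the scatter) is therefore small, in no direction that the scatter would confirm.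

For compound 4 the estimated value is -25%, with a likely range from -45% to -5%.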

Compound 4, a percentage reported as activity, at one concentration (the size of the read-out at that concentration, not a potency): -9.21%
The estimate for compound 4 lay 15.8 percentage points below the measured number; measured number inside the range.
By their numbers in this assay, from the lowest: compounds 1, 2 and 3 (each within the scatter of the next, the first and the last beyond it); then compound 4.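

Replacing the chloro with hydrogen turns the 4-chloro-3-(trifluoromethyl)phenyl group into 3-(trifluoromethyl)phenyl, and in this assay this gives a number 21.6 percentage points higher from compound 3 to compound 4 (beyond the scatter), a weaker effect at the one concentration tested. For the compounds shown here, this is the first step on this ring to lie beyond the scatter, whereas the earlier change on the same ring, a number 9.2 percentage points higher from compound 1 to compound 2 (within the scatter), swapped trifluoromethyl for chloro and stayed within it, so this ring is not as indifferent as that single step suggested. The two steps differ in the group changed and in the compounds they start from, so they show only that removing this chloro can matter in the methoxy series, and no measurement here explains why.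

From the compounds shown here alone, it remains open whether the same removal would weaken the effect as much in compound 1, which carries a hydroxy group where compound 3 carries a methoxy group. Going by these compounds, it is also open whether a fluoro, a methyl or an amine on that aromatic carbon would behave like the chloro or like the hydrogen.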